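A few compounds are considered here, and "the series" means these few. Any claim that something is new, unique, unknown or untested is made for them only; others in the source may bear on it.

Compound 3 `CCCCCCCCc1nc(-c2ccc(CNC(=O)[C@H]3NCC[C@@H]3O)cc2)no1`, with an octyl chain on the shared core, gives 86 nM in an assay on isolated protein for inhibition of sphingosine kinase 1 (Homo sapiens); a higher number here means a weaker inhibitor, a lower number a stronger inhibitor. Among the three measured compounds it stands second highest: compound 1 `CCCCCCc1nc(-c2ccc(CNC(=O)[C@H]3NCC[C@@H]3O)cc2)no1`, the hexyl analogue, gives 49 nM, and compound 2 `CC1(c2nc(-c3ccc(CNC(=O)[C@H]4NCC[C@@H]4O)cc3)no2)CCCCC1`, carrying a 1-methylcyclohexyl group, gives 210 nM. The steps of a 1.8-fold higher number from compound 1 to compound 3 (0.24 log units; within the scatter) and a 2.4-fold lower number from compound 2 to compound 3 (0.39 log units; beyond the scatter) frame where compound 3 lies.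

Compound 4 `CCCCCc1nc(-c2ccc(CNC(=O)[C@H]3NCC[C@@H]3O)cc2)no1` shortens the chain further: hydrogen in place of propyl on a saturated chain carbon, five bonds along the chain from an aromatic carbon, so that a pentyl chain remains. Within the data shown here, the only measured step that bears on chain length is the one from hexyl to octyl, a 1.8-fold higher number from compound 1 to compound 3 (0.24 log units; within the scatter), which stayed within the scatter. No measured compound carries a chain shorter than hexyl, so the effect of going below that length is not shown. On this basis compound 4 is expected to give a number close to those of compound 1 and compound 3, with a 1.2-fold lower number from compound 3 to compound 4 (0.09 log units; within the scatter) the estimated step. The value estimated for compound 4 in this assay is 70 nM, within a range of 30 nM to 200 nM.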

Compound 4, half-maximal inhibitory concentration: 430 nM
Beside the measured number, compound 4's estimate is 6.1-fold (0.79 log units) below it, and the stated range ends below it.
By their numbers in this assay, from the lowest: compounds 1 and 3 (each within the scatter of the next); then compound 2; then compound 4.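

The chain at this position turns out not to be tolerant of every length: the change from hexyl to pentyl gives an 8.8-fold higher number from compound 1 to compound 4 (0.94 log units; beyond the scatter), whereas the earlier change from hexyl to octyl stayed within the scatter. Shortening from octyl to pentyl shows the same loss, with a 5.0-fold higher number from compound 3 to compound 4 (0.70 log units; beyond the scatter), so the two longer chains stand together and the pentyl chain stands apart from both. Compound 4 is the weakest of the four, and it even falls behind the 1-methylcyclohexyl group, with a 2.0-fold higher number from compound 2 to compound 4 (0.31 log units; beyond the scatter).

The compounds shown leave open whether a heptyl or a butyl chain would sit with compound 1 and compound 3 or with compound 4, and how a chain carrying an amine would compare. Nothing given here accounts for the sharp drop at pentyl.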